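A Ureido Swap in a Flat Series

The source may hold more compounds than are shown below. What is called first, only, known or untested is meant among the compounds shown, and "the series" means these compounds.

In a functional assay on G-361 cells (Homo sapiens) for cytotoxicity, read by MTT assay, with a stated time of 3 days (on this read-out higher numbers stand for weaker inhibition and lower numbers for stronger inhibition), compound 1 `N#Cc1c(Cl)nc(SCc2nc3ccccc3[nH]2)nc1-c1ccccc1` gives 12.5 nM, compound 2 `N#Cc1c(NN)nc(SCc2nc3ccccc3[nH]2)nc1-c1ccccc1` gives 14.7 nM, and compound 3 `N#Cc1c(Nc2ccccn2)nc(SCc2nc3ccccc3[nH]2)nc1-c1ccccc1` gives 8.9 nM. Compound 3 therefore stands within the scatter of both others, as a 1.4-fold lower number from compound 1 to compound 3 (0.15 log units; within the scatter) and a 1.7-fold lower number from compound 2 to compound 3 (0.22 log units; within the scatter) show. Compound 4 `N#Cc1c(NC(N)=O)nc(SCc2nc3ccccc3[nH]2)nc1-c1ccccc1` carries carbamoyl in place of pyridin-2-yl on a nitrogen on an aromatic ring. Going by the values given here, the closest precedent, a 1.7-fold lower number from compound 2 to compound 3 (0.22 log units; within the scatter), also exchanges a group on that nitrogen, while a 1.2-fold higher number from compound 1 to compound 2 (0.07 log units; within the scatter) likewise stays within the scatter. No step beyond the scatter is therefore expected in this assay. The expected change is a 1.5-fold higher number from compound 3 to compound 4 (0.16 log units; within the scatter). For compound 4 the estimated value is 13 nM, with an expected range from 6 nM to 28 nM.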

Compound 4, half-maximal inhibitory concentration: 2.55 nM
Estimate against measurement, compound 4: 5.1-fold (0.71 log units) above; measured number outside the range, below it.
By their numbers in this assay, from the lowest: compound 4; then compounds 3, 1 and 2 (each within the scatter of the next).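

Among the earlier compounds, chloro, aminoamino and (pyridin-2-yl)amino stayed within the scatter of each other, so this position had shown no response to its substituent in this assay. Ureido is the first group to separate from the rest, with a step from each of them beyond the scatter (a 3.5-fold lower number from compound 3 to compound 4 (0.54 log units; beyond the scatter); a 5.8-fold lower number from compound 2 to compound 4 (0.76 log units; beyond the scatter); a 4.9-fold lower number from compound 1 to compound 4 (0.69 log units; beyond the scatter)). Nothing available bears on why carbamoyl on this nitrogen has this effect.

As far as these compounds go, it remains open whether acetyl or methylcarbamoyl on that nitrogen would hold the lower number.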